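This account rests on a few compounds, and the source may have more. Where it says the series, first, only, none or still open, it means among the compounds named here.

Compound 3, `COCC1=C[C@@](C)(c2cc(NC(=O)c3ccc(C#N)cn3)ccc2F)N=C(N)O1`, gives 61% in an ADME assay on microsomes from liver (Rattus norvegicus, strain Crj;CD(SD)) for metabolic stability, read by LC-MS, using NADPH, with a stated time of 30 min, tested at 0.1 uM (on this read-out lower numbers stand for a less stable compound and higher numbers for a more stable compound), which is the highest of the three numbers available. Its nearest neighbour is compound 1, `C[C@@]1(c2cc(NC(=O)c3cnc(OCF)cn3)ccc2F)C=C(CF)OC(N)=N1`, which in this assay gives 52%, a gap that lies within the scatter, so the two cannot be ordered. Furthest away is compound 2, `COc1cnc(C(=O)Nc2ccc(F)c([C@]3(C)C=C(CF)OC(N)=N3)c2)cn1`, which in this assay gives 13%, a gap that lies beyond the scatter.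

Compound 4, `C[C@@]1(c2cc(NC(=O)c3ccc(C#N)cn3)ccc2F)C=C(CF)OC(N)=N1`, is not yet measured. It differs from compound 3 in one place: fluoro in place of methoxy on a saturated chain carbon bound to a double-bonded ring carbon.

For the measured compounds named here, only one measured step is available, and it concerns a different change at a different place: a number 39 percentage points lower from compound 1 to compound 2 (beyond the scatter). It shows that a single fluorine can matter greatly in this series, but it does not transfer directly to the present change. Compound 1 already carries a fluoromethyl on the shared core and its number in this assay sits within the scatter of compound 3, which carries a methoxymethyl there, though the two also differ elsewhere. On this basis no step beyond the scatter is expected in this assay for compound 4; the estimated step is a number 3 percentage points lower from compound 3 to compound 4 (within the scatter). Compound 4 is therefore expected to give about 58%, within a range from 38% to 78%.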

Compound 4, percent of the compound remaining: 55%
The estimate for compound 4 lay 3 percentage points above the measured number; low and high end bracket the measured number.
By their numbers in this assay, from the lowest: compound 2; then compounds 1, 4 and 3 (each within the scatter of the next).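

In this assay, for the compounds shown here, the exchange of methoxymethyl for fluoromethyl, with the 5-cyanopyridin-2-yl group held constant, gave a number 6 percentage points lower from compound 3 to compound 4 (within the scatter) and so offered the first direct reading at this chain carbon, where the two groups could not be separated. With fluoromethyl held constant, the group on the carbonyl carbon gave two different outcomes: 5-cyanopyridin-2-yl in place of 5-methoxypyrazin-2-yl gave a number 42 percentage points higher from compound 2 to compound 4 (beyond the scatter) on this read-out, whereas in place of 5-(fluoromethoxy)pyrazin-2-yl it gave a number 3 percentage points higher from compound 1 to compound 4 (within the scatter) and left those two groups unordered. Among these four compounds, both large steps therefore arose from changes in the group on the carbonyl carbon, and none arose from the change at the chain carbon on the shared core.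

No measurement at hand explains any of these steps. Going by these compounds, it remains open whether a hydroxymethyl or a longer chain such as ethoxymethyl at this carbon would also stay within the scatter, and whether methoxymethyl and fluoromethyl would remain inseparable with 5-methoxypyrazin-2-yl on the carbonyl carbon.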